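Mono-chloro anilide probed on the pyridine N-oxide piperidine amide

A few compounds are considered here, and "the series" means these few. Any claim that something is new, unique, unknown or untested is made for them only; others in the source may bear on it.

Compound 1 `O=C(CN1CCC(c2cccc[n+]2[O-])CC1)Nc1ccc(F)cc1F` gives 103 nM in a functional assay on HEK293 cells for agonist activity at D(4) dopamine receptor (Homo sapiens), read by FLIPR; a lower number here means that less compound is needed, a higher number that more compound is needed for the effect.
Compound 2 `O=C(CN1CCC(c2cccc[n+]2[O-])CC1)Nc1cc(Cl)cc(Cl)c1` gives 160 nM in this assay.
Compound 3 `O=C(CN1CCC(c2cccc[n+]2[O-])CC1)Nc1ccccc1F` gives 270 nM in this assay.

Compound 3 carries the highest number of the three, separated from compound 1 by a 2.6-fold higher number from compound 1 to compound 3 (0.42 log units; beyond the scatter) but from compound 2 only by a 1.7-fold higher number from compound 2 to compound 3 (0.23 log units; within the scatter). Compound 4 `O=C(CN1CCC(c2cccc[n+]2[O-])CC1)Nc1cccc(Cl)c1` differs from compound 3 by 3-chlorophenyl in place of 2-fluorophenyl on an amide-type nitrogen. Going by the values given here, the nearest precedent is the step from a chlorinated anilide to compound 3, a 1.7-fold higher number from compound 2 to compound 3 (0.23 log units; within the scatter), which lies within the scatter; the measured change to compound 2, a 1.6-fold higher number from compound 1 to compound 2 (0.19 log units; within the scatter), is likewise small. Compound 4 is therefore expected to move by about a 1.5-fold lower number from compound 3 to compound 4 (0.18 log units; within the scatter) in this assay, not beyond the scatter. The estimated value of compound 4 is 180 nM, with a range from 80 nM to 450 nM.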

Compound 4, half-maximal effective concentration: 62 nM
Estimate against measurement, compound 4: 2.9-fold (0.46 log units) above; the measured number lies below the stated range.
By their numbers in this assay, from the lowest: compounds 4, 1, 2 and 3 (each within the scatter of the next, the first and the last beyond it).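

Going by these compounds alone, the group on the amide-type nitrogen matters more than the earlier compounds suggested: 3-chlorophenyl in place of 2-fluorophenyl gives a 4.4-fold lower number from compound 3 to compound 4 (0.64 log units; beyond the scatter), the largest step so far in this assay. Removing one chloro from 3,5-dichlorophenyl also gives a 2.6-fold lower number from compound 2 to compound 4 (0.41 log units; beyond the scatter), whereas 3-chlorophenyl in place of 2,4-difluorophenyl gives only a 1.7-fold lower number from compound 1 to compound 4 (0.22 log units; within the scatter), which stays within the scatter. Nothing available accounts for these differences.

The compounds shown leave open whether the chloro itself or its place on the ring drives the step. A 3-fluorophenyl, 3-methylphenyl or 2-chlorophenyl group would bear on that question.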